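From Compound 3 to Compound 4: A Benzyl for a Methyl

The compounds below may be only part of what the source reports. "The series", "measured", "known", "first", "only" and "open" are said of these compounds alone.

Compound 1 `CN(C)C(=S)SC(=S)N1CCN(c2cccc(Cl)c2)CC1` gives in an ADME assay on HeLa cells (Homo sapiens) for cytotoxicity, read by MTT assay, with a stated time of 24 h; a higher number here means a weaker inhibitor, a lower number a stronger inhibitor > 5000000 nM, which is a limit of the assay rather than a number.
Compound 2 `CN(C)C(=S)SC(=S)N1CCN(c2ncccn2)CC1` gives in this assay > 5000000 nM, likewise a limit.
Compound 3 `CSC(=S)N1CCN(C(=S)SC(=S)N(C)C)CC1` gives in this assay > 5000000 nM, also a limit.

The three measured compounds share one core and differ only in the group on the amine nitrogen in the ring. Because all of them sit at the limit of > 5000000 nM in this assay, at which 3 of the 3 values shown sit, none of the steps between them can be read: a step that the two limits leave unreadable from compound 1 to compound 2, a step that the two limits leave unreadable from compound 1 to compound 3 and a step that the two limits leave unreadable from compound 2 to compound 3 are all of unreadable size. Compound 3 thus stands only at the limit; no number is known for it.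

Compound 4 `CN(C)C(=S)SC(=S)N1CCN(C(=S)SCc2ccccc2)CC1` differs from compound 3 by phenyl in place of hydrogen on a saturated chain carbon bound to a sulfur; cut one bond further out, this reads methyl to benzyl, methylsulfanyl to benzylsulfanyl. Going by the values given here, none of the measured steps touches this part of the molecule, and all of them were unreadable anyway, so no step bears on the change in a readable way.

Compound 4 is therefore expected to stay at the limit as well, at an estimated 5000000 nM with a range from 1000000 nM to 20000000 nM. The expected step of a number no higher from compound 3 to compound 4 (the limit leaves the size open) is estimated as none beyond the scatter.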

Compound 4, half-maximal inhibitory concentration: > 5000000 nM
Compound 4 was reported as a limit; the forecaster's own chance of this, stated with the estimate: 85%; the middle value sits exactly at the limit.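

Compound 4 is reported only as a limit, as compound 3 is, so the change from methyl to benzyl gives no step that can be read: the limit of > 5000000 nM in this assay, at which 4 of the 4 values shown sit.

The compounds shown leave open what number any of them would give in this assay, and whether any group on the shared core alters that read-out at all.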